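This account rests on a few compounds, and the source may have more. Where it says the series, first, only, none or still open, it means among the compounds named here.

Series notes. Of the compounds shown here, three so far carry a number in a functional assay on the whole organism for inhibition, with Chlorella vulgaris as the target, read by spectrophotometry, with a stated time of 4 h; a lower number here means a stronger inhibitor, a higher number a weaker inhibitor. Compound 1 `CCCc1cnc(C(=O)/C=C/c2ccc(O)cc2)cn1` gives 514000 nM in this assay, the highest of the three numbers recorded. Compound 3 `CC(C)(C)c1cnc(C(=O)Nc2cccc(O)c2)cn1` gives 329000 nM in this assay; the gap between compound 1 and compound 3 stays within the scatter, so the two cannot be ordered. Compound 2 `CCCCc1cnc(C(=O)/C=C/c2ccccc2O)cn1` gives 147000 nM in this assay, and here the gap to compound 1 lies beyond the scatter. Compound 2 and compound 3 each differ from compound 1 in more than one place, so none of these pairs yields a single-point step, and nothing can be read from them about the change in hand.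

Compound 4 `CC(C)c1cnc(C(=O)/C=C/c2ccc(O)cc2)cn1` has not yet been measured in this assay. Its difference from compound 1 is counted as isopropyl in place of propyl on an aromatic carbon. The two have the same atoms, joined differently. Among the compounds with values here, with no single-point step anywhere among the measured compounds, there is nothing to scale such a change against; a step of this kind is expected to fall within the scatter, in no settled direction. Compound 4 is therefore expected to give about 450000 nM in this assay, with a range from 200000 nM to 1000000 nM. The step this estimate implies, a 1.1-fold lower number from compound 1 to compound 4 (0.06 log units; within the scatter), is expected to sit within the usual scatter.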

Compound 4, half-maximal inhibitory concentration: 279000 nM
Compound 4: middle estimate off by 1.6-fold (0.21 log units), on the high side, and the stated range covers the measured number.
By their numbers in this assay, from the lowest: compounds 2, 4, 3 and 1 (each within the scatter of the next, the first and the last beyond it).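

In this assay, the series now has its first single-point step: isopropyl in place of propyl on an aromatic carbon, next to the ring nitrogen and para to a large group, gives a 1.8-fold lower number from compound 1 to compound 4 (0.27 log units; within the scatter). Compound 1 and compound 4 therefore cannot be ordered, so with the rest of the core of compound 1 held fixed, joining the same atoms differently at this position produces no readable change, and this single pair gives no direction for the exchange. No further data accompany this step that would bear on the result.

As far as these compounds go, it remains open whether a longer chain such as hexyl, or a group of another kind such as an amine or a carboxylic acid, at this same position would move the number beyond the scatter in this assay. Also open, from the compounds shown here alone, is whether the exchange of propyl for isopropyl would behave the same way with the hydroxyl on the other aromatic ring placed elsewhere, or with an amide link in place of the chain carrying that ring.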